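The source may hold more compounds than are shown below. What is called first, only, known or untested is meant among the compounds shown, and "the series" means these compounds.

Values in a functional assay on MCF7 cells (Homo sapiens) for cytotoxicity, read by MTT assay, with a stated time of 72 h; on this read-out higher numbers stand for weaker inhibition and lower numbers for stronger inhibition:

- Compound 1 `N[C@H]1CC[C@H](Nc2c(C(=O)NCc3ccc(Oc4ccccc4)cc3)nc(Br)c3cccnc23)CC1` gives 7900 nM
- Compound 2 `CN(C)c1ccc(CNC(=O)c2nc(Br)c3cccnc3c2N[C@H]2CC[C@H](N)CC2)cc1` gives 5000 nM
- Compound 3 `CS(=O)(=O)NCCCN(c1nc(C(=O)NCc2ccc(F)cc2)c(O)c2ncccc12)S(C)(=O)=O` gives > 20000 nM, which is a limit of the assay and not a number

Only compound 1 and compound 2 have actual numbers in this assay, and these two lie within the scatter of each other. Compound 2 therefore stands level with compound 1 on the numbers available. Compound 4 `N[C@H]1CC[C@H](Nc2c(C(=O)NC3CCCCC3)nc(Br)c3cccnc23)CC1` departs from compound 2 at the amide, where the change is cyclohexyl in place of 4-(dimethylamino)benzyl on an amide-type nitrogen. In words, cyclohexyl takes the place of 4-(dimethylamino)benzyl on an amide-type nitrogen.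

Going by the values given here, one measured step bears on this, as it also alters the group carried on that amide. It is a 1.6-fold lower number from compound 1 to compound 2 (0.20 log units; within the scatter), with dimethylamino in place of phenoxy on an aromatic carbon. Among the compounds with values here, that step leaves the aromatic ring in place, so no measured pair shows what replacing the whole benzyl group does. No single change links compound 3 to the other compounds.

Within the data shown here, with only that small step as a guide, no shift beyond the scatter is expected, though the uncertainty is wide. The expected step is a 1.4-fold higher number from compound 2 to compound 4 (0.15 log units; within the scatter). For compound 4 the estimated value is 7000 nM. The expected range for this compound runs from 2500 nM to 20000 nM.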

Compound 4, half-maximal inhibitory concentration: 5200 nM
Estimate against measurement, compound 4: 1.3-fold (0.13 log units) above; low and high end bracket the measured number.
By their numbers in this assay, from the lowest: compounds 2, 4 and 1 (each within the scatter of the next). At a limit, above all of these: compound 3.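

In this assay the exchange of 4-(dimethylamino)benzyl for cyclohexyl on the amide-type nitrogen comes to a 1.0-fold higher number from compound 2 to compound 4 (0.02 log units; within the scatter) and so shows that the number stays within the scatter even when the whole group leaves, its aromatic ring included. The earlier pair altered only what that aromatic ring carried, whereas here a non-aromatic ring of carbon only, with fewer heavy atoms and no hydrogen-bond acceptor, takes its place and compound 2 and compound 4 still stand level. Nothing in the data shown gives a cause for this lack of a difference.

From the compounds shown here alone, what remains open is whether the number would also hold with no ring at all on this nitrogen, as with a methyl group or an n-butyl chain, or with a ring carrying a carboxylic acid or a primary amine. Going by these compounds, it is equally open whether any group at this place can move the number beyond the scatter in either direction, since the three groups compared so far on this amide all give values within the scatter of the next.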